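This account rests on a few compounds, and the source may have more. Where it says the series, first, only, none or still open, it means among the compounds named here.

Compound 3 `CC[C@@H]1C(=O)N(C)c2cnc(-n3ccc4cc(C(=O)NC)ccc43)nc2N1C1CCCC1` stands lowest of the three numbers in an assay for inhibition of serine/threonine-protein kinase PLK2 (Homo sapiens), read by FRET and Z'-LYTE, with a stated time of 1 h (a lower number here means a stronger inhibitor, a higher number a weaker inhibitor), where compound 3 gives 8.6 nM. Compound 1 `CC[C@@H]1C(=O)N(C)c2cnc(-n3ccc4ccccc43)nc2N1C1CCCC1` gives 355 nM in this assay, and compound 2 `CC[C@@H]1C(=O)N(C)c2cnc(-n3ccc4cc(F)ccc43)nc2N1C1CCCC1` gives 969 nM. The step of a 41-fold lower number from compound 1 to compound 3 (1.62 log units; beyond the scatter) and the step of a 110-fold lower number from compound 2 to compound 3 (2.05 log units; beyond the scatter) both place the methylcarbamoyl group at the heart of the gain, while the step of a 2.7-fold higher number from compound 1 to compound 2 (0.44 log units; beyond the scatter) shows a fluoro in that position moving the number the other way.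

Compound 4 `CCCNC(=O)c1ccc2c(ccn2-c2ncc3c(n2)N(C2CCCC2)[C@H](CC)C(=O)N3C)c1` differs from compound 3 by ethyl in place of hydrogen on a saturated chain carbon bound to an amide-type nitrogen, so that methylcarbamoyl becomes propylcarbamoyl. Within the data shown here, no measured step tests a change of this kind: the three steps all alter what sits on the aromatic carbon, not the chain on the amide nitrogen. The methylcarbamoyl group itself remains, and the steps to compound 3 give no ground to expect its effect to be lost or enlarged by a longer chain. The expected step from compound 3 to compound 4 in this assay is therefore a 1.3-fold higher number from compound 3 to compound 4 (0.11 log units; within the scatter), none beyond the scatter. Compound 4 is thus estimated at 11 nM, with a range from 4 nM to 35 nM.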

Compound 4, half-maximal inhibitory concentration: 11.4 nM
Compound 4: middle estimate off by 1.0-fold (0.02 log units), on the low side; the measured number falls inside the stated range.
By their numbers in this assay, from the lowest: compounds 3 and 4 (each within the scatter of the next); then compound 1; then compound 2.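

Ethyl in place of hydrogen on a saturated chain carbon bound to an amide-type nitrogen, which turns methylcarbamoyl into propylcarbamoyl, gives a 1.3-fold higher number from compound 3 to compound 4 (0.12 log units; within the scatter) in this assay and so does not separate the two compounds. Among these compounds, this is the first measured change to the chain on the amide nitrogen, and it shows that the large gain does not rest on methyl alone. That gain persists with propylcarbamoyl, as a 31-fold lower number from compound 1 to compound 4 (1.49 log units; beyond the scatter) and an 85-fold lower number from compound 2 to compound 4 (1.93 log units; beyond the scatter) both show in this assay for this carbamoyl chain.

On these data alone, whether a butyl chain, a cyclopropyl ring or a chain ending in an amine on that nitrogen, or a carboxylic acid in place of the whole carbamoyl group, would keep the gain remains open. No available evidence explains why these two chains on the amide nitrogen cannot be told apart.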